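Adding a Second Hydroxy Group to Compound 3

The compounds below may be only part of what the source reports. "The series", "measured", "known", "first", "only" and "open" are said of these compounds alone.

Of the compounds shown here, three sharing one core have been measured in a functional assay on MCF7 cells (Homo sapiens) for antiproliferative activity, read by MTT assay, with stated times of 24 h and 72 h; a higher number here means a weaker inhibitor, a lower number a stronger inhibitor. Compound 1 `COc1cc([C@@H]2[C@H](Oc3ccccc3)C(=O)N2c2cc(OC)c(OC)c(OC)c2)cc(OC)c1OC` gives 29000 nM, compound 2 `COc1cc(N2C(=O)[C@@H](Oc3ccccc3)[C@H]2c2ccc([S+](C)[O-])cc2)cc(OC)c1OC` gives 20000 nM, and compound 3 `COc1cc(N2C(=O)[C@@H](Oc3ccccc3)[C@H]2c2ccc(O)cc2)cc(OC)c1OC` gives 48000 nM. Two steps fix the place of compound 3: a 1.7-fold higher number from compound 1 to compound 3 (0.22 log units; within the scatter), and a 2.4-fold higher number from compound 2 to compound 3 (0.38 log units; beyond the scatter). Only compound 2 therefore stands clearly apart from it.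

Compound 4 `COc1cc(N2C(=O)[C@@H](Oc3ccccc3)[C@H]2c2ccc(O)c(O)c2)cc(OC)c1OC` is related to compound 3 by hydroxy in place of hydrogen on an aromatic carbon, ortho to a hydroxy group, so that 4-hydroxyphenyl becomes 3,4-dihydroxyphenyl.

Within the data shown here, no measured pair shows this change alone. The nearest evidence comes from the three measured variations of the same aromatic group, which include a 1.5-fold lower number from compound 1 to compound 2 (0.16 log units; within the scatter). Among these compounds, the largest step is the modest one between compound 2 and compound 3, so no step beyond the scatter is expected in this assay. The expected change is a 1.5-fold lower number from compound 3 to compound 4 (0.18 log units; within the scatter). Compound 4 is estimated at 32000 nM, with an expected range from 12000 nM to 90000 nM.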

Compound 4, half-maximal inhibitory concentration: 4500 nM
Compound 4: the middle estimate sits 7.1-fold (0.85 log units) above what was measured; the whole stated range lies above it.
By their numbers in this assay, from the lowest: compound 4; then compounds 2, 1 and 3 (each within the scatter of the next, the first and the last beyond it).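

In this assay, among these compounds, hydroxy in place of hydrogen on this aromatic carbon, ortho to a hydroxy group, gives an 11-fold lower number from compound 3 to compound 4 (1.03 log units; beyond the scatter) and thus the first large step, which the earlier variations of this aromatic group did not approach. The 3,4-dihydroxyphenyl group also separates compound 4 from the two other variants, with a 4.4-fold lower number from compound 2 to compound 4 (0.65 log units; beyond the scatter) and a 6.4-fold lower number from compound 1 to compound 4 (0.81 log units; beyond the scatter), so compound 4 is the strongest inhibitor of the four. No evidence on the reason for this gain is available.

As far as these compounds go, whether an amino group or a fluorine atom on the same carbon would give a step of similar size remains open. So does whether the new hydroxy group would have the same effect on a phenyl ring without the existing hydroxy group.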